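The source may hold more compounds than are shown below. What is called first, only, known or untested is meant among the compounds shown, and "the series" means these compounds.

Measured so far:
compound 1 `O=C(NO)c1ccc(N(Cc2ccc(C3CCOCC3)cc2)C(=O)[C@H]2CCN2S(=O)(=O)c2c(F)c(F)c(F)c(F)c2F)cc1O` — an ADME assay on MCF-10A cells (Homo sapiens) for cytotoxicity, with a stated time of 72 h; a lower number here means that less compound is needed, a higher number that more compound is needed for the effect: "not determined" (no result reported)
compound 2 `O=C(NO)c1ccc(N(Cc2ccc(C3CCCCC3)cn2)C(=O)[C@H]2CCN2S(=O)(=O)c2c(F)c(F)c(F)c(F)c2F)cc1O` — this assay: "not determined" (no result reported)
compound 3 `O=C([C@H]1CCN1S(=O)(=O)c1c(F)c(F)c(F)c(F)c1F)N(Cc1ccc(C2CCCCC2)cc1)c1ccc2c(=O)[nH]ncc2c1` — this assay: 4600 nM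

Compound 2 has no number in this assay; the same holds for compound 1, so nothing can be said about where compound 2 stands relative to the others. For the measured compounds named here, the only number in the set belongs to compound 3, which gives 4600 nM in this assay.

Compound 4 `O=C([C@H]1CCN1S(=O)(=O)c1c(F)c(F)c(F)c(F)c1F)N(Cc1ccc(C2CCCCC2)cn1)c1ccc2c(=O)[nH]cnc2c1` is not yet measured. It differs from compound 2 as follows: a group of 11 heavy atoms (8 carbon, 2 nitrogen, 1 oxygen; one six-membered aromatic ring of carbon only, one six-membered aromatic ring with 2 hetero atoms) in place of a group of 11 heavy atoms (7 carbon, 1 nitrogen, 3 oxygen; one six-membered aromatic ring of carbon only), on an amide-type nitrogen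

Going by the values given here, no step between measured compounds exists for this change, so the size of the step from compound 2 to compound 4 cannot be read off. A value of the same order as that of compound 3 is expected for compound 4, because compound 3 gives 4600 nM and shares most of its framework with compound 4; a direction cannot be stated, and nothing beyond the usual scatter is expected. Compound 4 is estimated to give 5000 nM in this assay, with an expected range of 1500 nM to 16000 nM.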

Compound 4, half-maximal effective concentration: 4000 nM
The estimate for compound 4 lay 1.3-fold (0.10 log units) above the measured number, and the stated range covers the measured number.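

For the compounds shown here, compound 2 has no single number to set against compound 4, so no step between these two compounds can be read. The compounds shown leave open what exchanging the 3-hydroxy-4-(hydroxycarbamoyl)phenyl group on the amide-type nitrogen does on its own, and no supporting data bear on this result.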